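A few compounds are considered here, and "the series" means these few. Any claim that something is new, unique, unknown or untested is made for them only; others in the source may bear on it.

Of the compounds shown here, three of a shared core have been measured in a functional assay on Hypothalamus for inhibition of Norepinephrine transporter (Rattus norvegicus); on this read-out higher numbers stand for weaker inhibition and lower numbers for stronger inhibition. Compound 1, `CN[C@@H]1CC[C@@H](c2ccc(Cl)cc2Cl)c2ccccc21`, gives 970 nM; compound 2, `CCCCOc1ccc([C@@H]2CC[C@@H](NC)c3ccccc32)cc1`, gives 1150 nM, a number within the usual scatter of that of compound 1; compound 3, `CN(C)[C@@H]1CC[C@@H](c2ccccc2)c2ccccc21`, gives 140 nM, a clearly lower number. Compound 1 thus stands second highest of the three numbers. The next compound, compound 4, `CN[C@H]1CC[C@@H](c2ccc(Cl)cc2Cl)c2ccccc21`, differs from compound 1 as follows: the two compounds have the same atoms and bonds and differ only in configuration as drawn: 1 of 2 stereo elements differ; a stereocentre at a saturated ring carbon is drawn R in compound 1 and S in compound 4. Among the measured compounds shown here, no measured pair here changes only this configuration, so the size of the effect is open; a modest move to a lower number is expected, as a 2.8-fold lower number from compound 1 to compound 4 (0.44 log units; beyond the scatter). For compound 4 in this assay the estimate is 350 nM, between 80 nM and 1500 nM.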

Compound 4, half-maximal inhibitory concentration: 310 nM
For compound 4 the middle estimate is 1.1-fold (0.05 log units) above the measured one, and the stated range covers the measured number.
By their numbers in this assay, from the lowest: compound 3; then compound 4; then compounds 1 and 2 (each within the scatter of the next).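

Among the earlier compounds, no pair isolated a single stereocentre. In this assay, a 3.1-fold lower number from compound 1 to compound 4 (0.50 log units; beyond the scatter) shows that the configuration at this saturated ring carbon matters on its own, with the S form as drawn giving the lower number. The step can be assigned to this stereocentre alone because no atom or bond changes: the fact that compounds 1 and 4 differ only in the configuration as drawn

The compounds shown leave open whether the same switch moves the number similarly in compound 2 or compound 3. Also open, on these data alone, is how a primary amine in place of the methylamino group would behave in either configuration.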